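The source may report more compounds than this note shows. Statements on the series, on what has been measured and on what is new or still open speak of the compounds shown alone.

Measured in a functional assay on SH-SY5Y cells (Homo sapiens) for cytotoxicity, read by MTT assay; a higher number here means a weaker inhibitor, a lower number a stronger inhibitor:
- compound 1 `COc1ccc(-c2cocc2-c2cc(OC)c(OC)c(OC)c2)cc1` gives 39 nM
- compound 2 `COc1ccc(-c2cocc2-c2cc(OC)c(OC)c(OC)c2)cc1O` gives 2.9 nM
- compound 3 `COc1ccc(-c2c(-c3cc(OC)c(OC)c(OC)c3)coc2C=O)cc1` gives 231 nM

Compound 3, at 231 nM, has the highest number of the three and is the weakest inhibitor here. Compound 4 `COc1ccc(-c2c(-c3cc(OC)c(OC)c(OC)c3)coc2/C=N/NC(=O)CCCC(=O)O)cc1` is not yet measured. It differs from compound 3 by a group of 11 heavy atoms (6 carbon, 2 nitrogen, 3 oxygen; no ring) in place of a group of 2 heavy atoms (1 carbon, 1 oxygen; no ring), on an aromatic carbon, next to the ring oxygen. The closest guide is the modest 5.9-fold higher number from compound 1 to compound 3 (0.77 log units; beyond the scatter), where formyl replaced hydrogen on that carbon. The large 13-fold lower number from compound 1 to compound 2 (1.13 log units; beyond the scatter) came from a hydroxy group elsewhere, so it bears less. For the measured compounds named here, no measured step replaces formyl itself, so this is a rough guide, and a modest further rise in the number is expected. The estimated change is a 2.2-fold higher number from compound 3 to compound 4 (0.34 log units; beyond the scatter). Compound 4 is expected at 500 nM, within a range of 100 nM to 2500 nM.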

Compound 4, half-maximal inhibitory concentration: 1670 nM
The estimate for compound 4 lay 3.3-fold (0.52 log units) below the measured number, and the stated range covers the measured number.
By their numbers in this assay, from the lowest: compound 2; then compound 1; then compound 3; then compound 4.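

On the aromatic carbon next to the ring oxygen, replacing formyl with the longer chain gives a 7.2-fold higher number from compound 3 to compound 4 (0.86 log units; beyond the scatter) and hydrogen to that chain gives a 43-fold higher number from compound 1 to compound 4 (1.63 log units; beyond the scatter) overall. Both groups tried on this carbon therefore give weaker inhibitors than hydrogen, and the larger group gives the weaker of the two. No measured evidence here explains this rise.

Open, going by these compounds, is whether a small methyl or an amine on this carbon would keep the number close to that of compound 1. Also open, on these data alone, is how a shorter chain ending in a carboxylic acid would compare with compound 4.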